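Aryl step from compound 3 to compound 4

The source may report more compounds than this note shows. Statements on the series, on what has been measured and on what is new or still open speak of the compounds shown alone.

In a functional assay on UACC-62 cells (Homo sapiens) for cytotoxicity, read by sulforhodamine B assay (on this read-out lower numbers stand for higher toxicity in this test and higher numbers for lower toxicity in this test), compound 1 `COc1ccc(/C=N\NC(=S)NC(C)(C)CCC[C@](C)(O)[C@@H]2CC=C(C)CC2)cc1` gives 48500 nM and compound 2 `CC1=CC[C@@H]([C@@](C)(O)CCCC(C)(C)NC(=S)N/N=C\c2ccc(O)cc2)CC1` gives 55600 nM while compound 3 `CC1=CC[C@@H]([C@@](C)(O)CCCC(C)(C)NC(=S)N/N=C\c2ccccc2[N+](=O)[O-])CC1` gives 49300 nM in the same test. Compound 3 thus stands level with the other two, all three values lying within the scatter of each other.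

Compound 4 `CC1=CC[C@@H]([C@@](C)(O)CCCC(C)(C)NC(=S)N/N=C\c2cccc(Cl)c2)CC1` is still unmeasured. Its difference from compound 3 is 3-chlorophenyl in place of 2-nitrophenyl on a carbon with a double bond to nitrogen and in words this is 3-chlorophenyl in place of 2-nitrophenyl on a carbon with a double bond to nitrogen.

Within the data shown here, three measured steps bear on this change. Replacing the group on that carbon gave a 1.0-fold higher number from compound 1 to compound 3 (0.01 log units; within the scatter) and also a 1.1-fold lower number from compound 2 to compound 3 (0.05 log units; within the scatter) while the change on the aromatic oxygen gave a 1.1-fold higher number from compound 1 to compound 2 (0.06 log units; within the scatter) as the third step. Among the measured compounds shown here, all three lie within the scatter, although no measured compound carries a 3-chlorophenyl group. In this assay no step beyond the scatter and no clear direction is therefore expected. The expected step is a 1.0-fold higher number from compound 3 to compound 4 (0.01 log units; within the scatter) and no more than that. Compound 4 is estimated at 50000 nM with an expected range of 30000 nM to 80000 nM on this read-out.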

Compound 4, concentration lethal to 50% of the cells: 42700 nM
Beside the measured number, compound 4's estimate is 1.2-fold (0.07 log units) above it; the range from low to high includes it.
By their numbers in this assay, from the lowest: compounds 4, 1, 3 and 2 (each within the scatter of the next).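

In this assay, 3-chlorophenyl on a carbon with a double bond to nitrogen gives a 1.2-fold lower number from compound 3 to compound 4 (0.06 log units; within the scatter), along with a 1.3-fold lower number from compound 2 to compound 4 (0.11 log units; within the scatter) and a 1.1-fold lower number from compound 1 to compound 4 (0.06 log units; within the scatter). This position has therefore taken four different aryl groups, now including a chlorine-bearing ring, with every step among them within the scatter; 3-chlorophenyl, with no hydrogen-bond acceptors, stands level with 2-nitrophenyl, which has them. No supporting data bear on why the values stay this close.

As far as these compounds go, whether a phenyl ring carrying an amine or a carboxylic acid, or a longer alkyl chain in place of the ring, would move the number beyond the scatter stays open. Any change away from this carbon, on the rest of the shared core, also stays open.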